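The source may report more compounds than this note shows. Statements on the series, on what has been measured and on what is new or still open speak of the compounds shown alone.

Working notes on the series in a functional assay on J774 cells (Mus musculus) for cytotoxicity, with a stated time of 48 h; a higher number here means a weaker inhibitor, a lower number a stronger inhibitor. Compound 1 `CC(C)C[C@@H](NC(=O)OC(C)(C)C)C(=O)N1CCC[C@H]1C(=O)N1[C@H](C(=O)OCc2ccccc2)[C@H]1C(=O)OCc1ccccc1` is the reference point; in this assay compound 1 gives only a limit, > 100000 nM, so no single number places it. Compound 2 `CC(C)C[C@H](NC(=O)OC(C)(C)C)C(=O)N1CCC[C@H]1C(=O)N1[C@H](C(=O)O)[C@H]1C(=O)O` has "not determined" (no result reported) in this assay. Among the measured compounds shown here, compound 3 `CC(C)C[C@H](NC(=O)OC(C)(C)C)C(=O)N1CC[C@@H]1C(=O)N1[C@H](C(=O)OCc2ccccc2)[C@H]1C(=O)OCc1ccccc1` gives 37200 nM in this assay; it differs from compound 1 in more than one place, so no single step links the two, and their values show only that compound 3 has a single number where compound 1 does not. Compound 4 `CC(C)C[C@H](NC(=O)OC(C)(C)C)C(=O)N1CCC[C@@H]1C(=O)N1[C@H](C(=O)OCc2ccccc2)[C@H]1C(=O)OCc1ccccc1` is the stereoisomer still to be measured; relative to compound 1 the change is the two compounds have the same atoms and bonds and differ only in configuration as drawn: 2 of 4 stereo elements differ; a stereocentre at a saturated chain carbon is drawn R in compound 1 and S in compound 4; a stereocentre at a saturated ring carbon is drawn S in compound 1 and R in compound 4. With compound 1 sitting at the limit of > 100000 nM in this assay, at which 1 of the 3 values shown sits, no measured step sizes the effect of such a change in configuration, and an unchanged limit is the most probable outcome. The expected step from compound 1 to compound 4 is a number no higher from compound 1 to compound 4 (the limit leaves the size open), that is none beyond the scatter. Compound 4 is therefore expected to give 100000 nM, in the range 30000 nM to 300000 nM, with a fair chance that this assay again reports only a limit.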

Compound 4, half-maximal inhibitory concentration: > 100000 nM
Compound 4: only a limit was reported; the forecaster's own chance of this, stated with the estimate: 65%; the middle value sits exactly at the limit.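

Compound 1 and compound 4 both give only a limit in this assay, so no step can be read between the two. The compounds shown leave open whether the difference in configuration between compound 1 and compound 4 changes the value in this assay at all.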